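Extending the Ring Nitrogen Chain of Compound 1

The source may hold more compounds than are shown below. What is called first, only, known or untested is meant among the compounds shown, and "the series" means these compounds.

Within the data shown here, the three compounds measured so far share one core and differ only in the group on an amide-type nitrogen in a ring. Compound 1 `CN1C(=O)NC2(CSC3=C2C(=O)c2ccccc2C3=O)C1=O` gives 23 nM in a functional assay on MCF7 cells (Homo sapiens) for inhibition (a higher number here means a weaker inhibitor, a lower number a stronger inhibitor), the lowest of the three numbers. Compound 2 `CCC(C)N1C(=O)NC2(CSC3=C2C(=O)c2ccccc2C3=O)C1=O` gives 178 nM, and compound 3 `CC(C)(C)N1C(=O)NC2(CSC3=C2C(=O)c2ccccc2C3=O)C1=O` gives 331 nM. The step of a 7.7-fold higher number from compound 1 to compound 2 (0.89 log units; beyond the scatter) and the step of a 14-fold higher number from compound 1 to compound 3 (1.16 log units; beyond the scatter) both lie beyond the scatter, while the step of a 1.9-fold higher number from compound 2 to compound 3 (0.27 log units; within the scatter) does not.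

Compound 4 `NCCCCN1C(=O)NC2(CSC3=C2C(=O)c2ccccc2C3=O)C1=O` is the next move from compound 1: 3-aminopropyl in place of hydrogen on a saturated chain carbon bound to an amide-type nitrogen in a ring. Seen from one bond further out, the change puts a 4-aminobutyl group where compound 1 has a methyl. Both measured steps from compound 1 bear on this, since each also replaced the methyl on that nitrogen, and each raised the number clearly. Among the measured compounds shown here, no measured step adds a hydrogen-bond donor or acceptor on this chain, so the data give no guide on that part of the change. A weakening beyond the scatter is therefore expected, of a size near those two steps; compound 4 is estimated at 150 nM, within 40 nM to 600 nM, which means an expected step of a 6.5-fold higher number from compound 1 to compound 4 (0.81 log units; beyond the scatter).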

Compound 4, half-maximal inhibitory concentration: 35 nM
The estimate for compound 4 lay 4.3-fold (0.63 log units) above the measured number; measured number below the stated range.
By their numbers in this assay, from the lowest: compounds 1 and 4 (each within the scatter of the next); then compounds 2 and 3 (each within the scatter of the next).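

In this assay the 4-aminobutyl group on the amide-type nitrogen in a ring gives a 1.5-fold higher number from compound 1 to compound 4 (0.18 log units; within the scatter) when set against the methyl, so the rise seen with sec-butyl and tert-butyl does not follow from every replacement of the methyl at this position. The same chain stands clearly apart from both branched groups, with a 5.1-fold lower number from compound 2 to compound 4 (0.71 log units; beyond the scatter) and a 9.5-fold lower number from compound 3 to compound 4 (0.98 log units; beyond the scatter) as the two steps, so the particular group on this nitrogen matters and not merely the loss of the methyl. Nothing in the available data explains this difference between the chain and the branched groups.

The compounds shown leave open whether the amine of the 4-aminobutyl group contributes to this result or whether the unbranched chain alone would suffice, and a plain butyl group with no amine would separate the two. Also open, on these data alone, is whether the result holds for a shorter or longer aminoalkyl chain, or for a carboxylic acid in place of the amine.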